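Cytotoxicity of acid-chain biaryl amides: a fluorine shift

A few compounds are considered here, and "the series" means these few. Any claim that something is new, unique, unknown or untested is made for them only; others in the source may bear on it.

The measured compounds and their values:
Compound 1, `CC(C)N(Cc1cccc(OCCCCCC(=O)O)c1)C(=O)c1ccc(-c2ccc3[nH]ccc3c2)cc1`. In an ADME assay on BJ cells (Homo sapiens) for cytotoxicity, read by CellTiter-Glo and resazurin assay, with a stated time of 72 h (on this read-out lower numbers stand for an effect already at smaller amounts and higher numbers for an effect only at larger amounts of compound), compound 1 gives > 26000 nM, which is a limit of the assay and not a number.
Compound 2, `CC(C)N(Cc1cccc(OCCCCCC(=O)O)c1)C(=O)c1ccc(-c2ccc3c(c2)OCCO3)cc1`. In this assay compound 2 gives > 21900 nM, again a limit.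
Compound 3, `COc1cc(F)cc(-c2ccc(C(=O)N(Cc3cccc(OCCCCCC(=O)O)c3)C(C)C)cc2)c1`. In this assay compound 3 gives > 26000 nM, also a limit.

Compound 3 thus stands nowhere in particular: its value is a limit, and the two other values shown are limits as well. The steps between the measured compounds, a step that the two limits leave unreadable from compound 1 to compound 2, a step that the two limits leave unreadable from compound 1 to compound 3 and a step that the two limits leave unreadable from compound 2 to compound 3, cannot be read in size because each pair of limits hides the true gap, as the limit of > 21900 nM in this assay, at which 1 of the 3 values shown sits, and the limit of > 26000 nM in this assay, at which 2 of the 3 values shown sit, record.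

Compound 4 is `COc1ccc(F)c(-c2ccc(C(=O)N(Cc3cccc(OCCCCCC(=O)O)c3)C(C)C)cc2)c1`. It differs from compound 3 by 2-fluoro-5-methoxyphenyl in place of 3-fluoro-5-methoxyphenyl on an aromatic carbon. Within the data shown here, none of the measured steps carries a readable size, so nothing in the data points to any direction for this change. Since compound 1, compound 2 and compound 3 all sit at limits, compound 4 is expected to sit at a limit too, with a step that the limit leaves unreadable from compound 3 to compound 4 no readable step.

The estimate for compound 4 is 30000 nM, with a range from 15000 nM to 80000 nM.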

Compound 4, half-maximal effective concentration: > 26000 nM
Compound 4: no number, only a limit; the forecaster's own chance of this, stated with the estimate: 85%; the middle value is on the limit's open side.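

In this assay compound 4 gives > 26000 nM, which is a limit of the assay and not a number. None of the steps to compound 4 from compound 1, compound 2 or compound 3 can be read in size. The compounds shown leave open at what concentration, if any, these four compounds reach a half-maximal effect.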